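Side chain step from compound 3 to compound 4

This account rests on a few compounds, and the source may have more. Where it says the series, first, only, none or still open, it means among the compounds named here.

Three compounds on a shared core have numbers in a functional assay on a cell-free system (plasma, Homo sapiens) for inhibition, with Plasma (Rattus norvegicus) as the target; a higher number here means a weaker inhibitor, a lower number a stronger inhibitor. Compound 1 `CCCOc1ccc2c(N3CCNCC3)cc(=O)oc2c1C` gives 7770 nM, compound 2 `COCOc1ccc2c(N3CCNCC3)cc(=O)oc2c1C` gives 3500 nM, and compound 3 `CSCOc1ccc2c(N3CCNCC3)cc(=O)oc2c1C` gives 3400 nM. Compound 3 therefore stands level with compound 2, as a 1.0-fold lower number from compound 2 to compound 3 (0.01 log units; within the scatter) shows, and both sit clear of compound 1.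

Compound 4 `Cc1c(OCCOc2ccccc2)ccc2c(N3CCNCC3)cc(=O)oc12` has not yet been measured. It carries phenoxymethyl in place of methylsulfanyl on a saturated chain carbon bound to an oxygen on an aromatic ring. Cut one bond further out, the same difference reads (methylsulfanyl)methyl to 2-phenoxyethyl.

Three measured steps fall at this place. Methoxy in place of ethyl gives a 2.2-fold lower number from compound 1 to compound 2 (0.35 log units; beyond the scatter), and methylsulfanyl in place of ethyl gives a 2.3-fold lower number from compound 1 to compound 3 (0.36 log units; beyond the scatter). Both steps are modest. None of the three measured compounds carries a ring in this chain, so the series gives no direction for phenoxymethyl. For the measured compounds named here, the small size of these steps is the only guide, and it is a weak one for a change this large. No step beyond the scatter is expected, though the uncertainty is wide.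

The estimate amounts to an expected 1.0-fold higher number from compound 3 to compound 4 (0.01 log units; within the scatter). Compound 4 is expected at 3500 nM, with an estimated range of 1000 nM to 11000 nM.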

Compound 4, half-maximal inhibitory concentration: 14300 nM
Beside the measured number, compound 4's estimate is 4.1-fold (0.61 log units) below it; measured number outside the range, above it.
By their numbers in this assay, from the lowest: compounds 3 and 2 (each within the scatter of the next); then compounds 1 and 4 (each within the scatter of the next).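

In this assay, the chain at this place is not indifferent to a ring: the phenoxymethyl end group gives a higher number than either short end group (a 4.2-fold higher number from compound 3 to compound 4 (0.62 log units; beyond the scatter)) and (a 4.1-fold higher number from compound 2 to compound 4 (0.61 log units; beyond the scatter)). Measured against the shorter all-carbon chain, phenoxy in place of methyl stays within the scatter (a 1.8-fold higher number from compound 1 to compound 4 (0.26 log units; within the scatter)), so the chain of compound 4 does not share the lower numbers of the methoxy and methylsulfanyl chains. An oxygen in the chain therefore does not alone go with those lower numbers, as compound 2 and compound 4 both carry one and still stand apart. No measurement in hand bears on why the number shifts at this position.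

The compounds shown do not separate the effect of the phenyl ring from that of the chain length, and a longer all-carbon chain such as pentyl, or a cyclohexyloxy end group in place of phenoxy, would bear on this. Also open, from the compounds shown here alone, is how the position responds to a charged or more strongly hydrogen-bonding end group, such as an amine or a carboxylic acid on the chain.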